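The compounds below may be only part of what the source reports. "The series", "measured", "known", "first", "only" and "open" are said of these compounds alone.

In a functional assay on CHO-K1 cells with Glucose-dependent insulinotropic receptor (Homo sapiens) as the target, read by a luciferase reporter, with a stated time of 5 h (on this read-out higher numbers stand for larger maximal responses and lower numbers for smaller maximal responses), compound 3 `COCCOC(=O)N1CCC(Oc2ncnc3c2CCN3c2ccc(S(C)(=O)=O)cc2F)CC1` gives 86%, the second highest of the three numbers measured. Its nearest neighbour is compound 2 `CC(C)(C)COC(=O)N1CCC(Oc2ncnc3c2CCN3c2ccc(S(C)(=O)=O)cc2F)CC1`, which gives 80%, a gap that lies within the scatter, as shown by a number 6 percentage points higher from compound 2 to compound 3 (within the scatter). The furthest is compound 1 `CCCOC(=O)N1CCC(Oc2ncnc3c2CCN3c2ccc(S(C)(=O)=O)cc2F)CC1`, which gives 111%; the step from it, a number 25 percentage points lower from compound 1 to compound 3 (beyond the scatter), lies beyond the scatter.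

Compound 4 `CN(C)S(=O)(=O)N1CCC(Oc2ncnc3c2CCN3c2ccc(S(C)(=O)=O)cc2F)CC1` differs from compound 3 by dimethylsulfamoyl in place of (2-methoxyethoxy)carbonyl on an amine nitrogen in a ring. All three measured steps change only the chain on the same amine nitrogen in a ring: a number 31 percentage points lower from compound 1 to compound 2 (beyond the scatter), a number 25 percentage points lower from compound 1 to compound 3 (beyond the scatter) and a number 6 percentage points higher from compound 2 to compound 3 (within the scatter). None of them exchanges a carbonyl-bearing group for a sulfamoyl group, so they bear on this step only loosely, showing that such changes can shift the largest response by a large or a modest amount, or not beyond the scatter. Among the compounds with values here, with no closer precedent, compound 4 is expected to stay near compound 3, with a number 1 percentage points lower from compound 3 to compound 4 (within the scatter), an estimated 85% within a wide range from 55% to 110%.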

Compound 4, largest response reached (reported as percent of maximum), in percent of the reference or control that the assay uses: 68%
Estimate against measurement, compound 4: 17 percentage points above; the range from low to high includes it.
By their numbers in this assay, from the lowest: compound 4; then compounds 2 and 3 (each within the scatter of the next); then compound 1.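

Exchanging the whole carbonyl-bearing group on the amine nitrogen in a ring for dimethylsulfamoyl lowers the largest response in this assay against all three earlier compounds: a number 18 percentage points lower from compound 3 to compound 4 (beyond the scatter), a number 12 percentage points lower from compound 2 to compound 4 (beyond the scatter) and a number 43 percentage points lower from compound 1 to compound 4 (beyond the scatter). The earlier steps shown here changed only the chain within that group, whereas this one shows that the group itself can be replaced while compound 4 still gives 68%, the lowest of the four numbers. Nothing measured here explains why the response falls with this exchange.

The compounds shown leave open whether the lower number goes with the sulfonyl link or with the dimethylamino end, as the two enter together. A urea carrying the same dimethylamino end on this nitrogen would help to tell these two parts apart.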